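Swapping a Thiazole Ether for a Benzyl Thioether

This account rests on a few compounds, and the source may have more. Where it says the series, first, only, none or still open, it means among the compounds named here.

Of the compounds shown here, three sharing one core have been measured in a functional assay on HEK293 cells for positive allosteric modulation of metabotropic glutamate receptor 5 (Homo sapiens), read by FLIPR and calcium flux; a lower number here means that less compound is needed, a higher number that more compound is needed for the effect. Compound 1 `O=C(COCc1ccccn1)N1CCN(c2ccc(Cl)cc2Cl)CC1` gives 310 nM, compound 2 `O=C(COCc1ncccn1)N1CCN(c2ccc(Cl)cc2Cl)CC1` gives 18000 nM, and compound 3 `O=C(COCc1cncs1)N1CCN(c2ccc(Cl)cc2Cl)CC1` gives 1280 nM, which places compound 3 second highest of the three. The measured steps of a 58-fold higher number from compound 1 to compound 2 (1.76 log units; beyond the scatter), a 4.1-fold higher number from compound 1 to compound 3 (0.62 log units; beyond the scatter) and a 14-fold lower number from compound 2 to compound 3 (1.15 log units; beyond the scatter) show that exchanging the aromatic ring alone moves the number strongly. Going by the values given here, compound 4 `O=C(CSCc1ccccc1)N1CCN(c2ccc(Cl)cc2Cl)CC1` differs from compound 3 by benzylsulfanyl in place of (1,3-thiazol-5-yl)methoxy on a saturated chain carbon bound to a carbonyl carbon, a change of both ring and linker that no measured step covers. The ring swaps already seen are large, so a sizeable move is expected in this assay, with direction uncertain. Compound 4 is estimated at 600 nM, between 100 nM and 4000 nM, which is expected to mean a 2.1-fold lower number from compound 3 to compound 4 (0.33 log units; beyond the scatter).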

Compound 4, half-maximal effective concentration: 7100 nM
Estimate against measurement, compound 4: 12-fold (1.07 log units) below, outside the stated range (above it).
By their numbers in this assay, from the lowest: compound 1; then compound 3; then compound 4; then compound 2.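

Benzylsulfanyl, with its ring of carbon only and its sulfur, gives a 5.5-fold higher number from compound 3 to compound 4 (0.74 log units; beyond the scatter) and a 23-fold higher number from compound 1 to compound 4 (1.36 log units; beyond the scatter) but a 2.5-fold lower number from compound 2 to compound 4 (0.40 log units; beyond the scatter). In this assay this group, so different from the three ethers, therefore lands inside the span they already set, and a ring without nitrogen does not give the highest number here. Nothing available explains this placing.

Ring and linker change together, so their separate shares stay open. So does how benzyloxy or (pyridin-2-yl)methylsulfanyl would behave at this place.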